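Dropping the Bromo Group from Compound 1

The source may hold more compounds than are shown below. What is called first, only, known or untested is meant among the compounds shown, and "the series" means these compounds.

Measured so far in a physicochemical assay for permeability; on this read-out higher numbers stand for higher permeability and lower numbers for lower permeability:
- compound 1 `Brc1ccc(NC2=NCCC3(CCCCC3)S2)cc1`: 90.3 10^-6 cm/s
- compound 2 `COc1ccc(NC2=NCCC3(CCCCC3)S2)cc1`: 1.11 10^-6 cm/s
- compound 3 `Fc1ccc(NC2=NCCC3(CCCCC3)S2)cc1Cl`: 7.36 10^-6 cm/s

Compound 1 stands highest of the three, and both others lie beyond the scatter below it. Compound 4 `c1ccc(NC2=NCCC3(CCCCC3)S2)cc1`, not yet measured, differs from compound 1 by hydrogen in place of bromo on an aromatic carbon, on an aromatic carbon para to a large group.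

Going by the values given here, the only measured step, an 81-fold lower number from compound 1 to compound 2 (1.91 log units; beyond the scatter), swaps the bromo group for a different substituent and is large, so it bears on this change only loosely; no step removes a substituent outright. Compound 3, carrying other halogens, gives a much lower number than compound 1. A downward step of moderate size is therefore expected, a 3.6-fold lower number from compound 1 to compound 4 (0.56 log units; beyond the scatter). Compound 4 is estimated at 25 10^-6 cm/s, within 8 10^-6 cm/s to 70 10^-6 cm/s.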

Compound 4, apparent permeability: 1.81 10^-6 cm/s
Compound 4: middle estimate off by 14-fold (1.14 log units), on the high side; measured number outside the range, below it.
By their numbers in this assay, from the lowest: compounds 2 and 4 (each within the scatter of the next); then compound 3; then compound 1.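

Taking the bromo group away and leaving only hydrogen is a large step in this assay, a 50-fold lower number from compound 1 to compound 4 (1.70 log units; beyond the scatter), so the shared core with hydrogen at this place does not reach the number of compound 1. Methoxy and hydrogen cannot be told apart here, since a 1.6-fold higher number from compound 2 to compound 4 (0.21 log units; within the scatter) lies within the usual scatter.

On these data alone, whether iodo or a nitrile on this carbon would give a number as high as that of compound 1 remains open. Nothing measured here explains why the bromo compound stands apart.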